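The source may hold more compounds than are shown below. What is called first, only, known or untested is meant among the compounds shown, and "the series" means these compounds.

Of the compounds shown here, three built on one shared core have so far been tested in a functional assay on CHO cells for agonist activity at Free fatty acid receptor 1 (Homo sapiens), read by FLIPR and calcium flux, tested at 100 nM; a lower number here means a weaker effect, a higher number a stronger effect of the compound at the concentration tested. Compound 1 `Cc1nc(-c2ccccc2)oc1COc1ccc2c(c1)OCC2CC(=O)O` gives 7.15%. Compound 2 `Cc1nc(-c2ccccc2)sc1COc1ccc2c(c1)OCC2CC(=O)O` gives 54.8%. Compound 3 `Cc1nc(-c2ccc(Cl)s2)sc1COc1ccc2c(c1)OCC2CC(=O)O` gives 8.34%. Among these three numbers compound 3 stands second highest; its value and that of compound 1 lie within the scatter of each other, while compound 2 sits far above it, as seen in the step of a number 46.5 percentage points lower from compound 2 to compound 3 (beyond the scatter), which came with 5-chlorothiophen-2-yl in place of phenyl on an aromatic carbon.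

Compound 4 `Cc1nc(-c2ccccc2Cl)sc1COc1ccc2c(c1)OCC2CC(=O)O` has not yet been measured. It differs from compound 3 in one place: 2-chlorophenyl in place of 5-chlorothiophen-2-yl on an aromatic carbon. The change brings back a six-membered aromatic ring of carbon only, as in compound 2, now carrying a chlorine. Among the compounds with values here, the one measured step that bears on this is a number 46.5 percentage points lower from compound 2 to compound 3 (beyond the scatter), which was large, and compound 4 largely reverses that change. A rise beyond the scatter is therefore expected. Within the data shown here, the chlorine on the entering ring has no counterpart among the measured compounds, so the expected step of a number 26.7 percentage points higher from compound 3 to compound 4 (beyond the scatter) is taken as less than a full return to the level of compound 2. Compound 4 is expected to give 35%, within a range from 10% to 65%.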

Compound 4, a percentage reported as activity, at one concentration (the size of the read-out at that concentration, not a potency): 12.4%
Compound 4: the middle estimate sits 22.6 percentage points above what was measured; low and high end bracket the measured number.
By their numbers in this assay, from the lowest: compounds 1, 3 and 4 (each within the scatter of the next); then compound 2.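

The step of a number 4.1 percentage points higher from compound 3 to compound 4 (within the scatter) shows that bringing back a six-membered aromatic ring of carbon only does not, with a chlorine on it, restore the level of compound 2. The step of a number 42.4 percentage points lower from compound 2 to compound 4 (beyond the scatter) shows that a single chloro in place of hydrogen on the phenyl ring is enough for a large loss, so the loss seen with compound 3 does not require the five-membered ring of 5-chlorothiophen-2-yl. No measurement explains why this one atom matters so much at this position.

Going by these compounds, it remains open whether the loss is specific to chloro or would also follow from another group on that ring, such as a methyl or a methoxy. On these data alone, the effect of the same chloro on the core of compound 1 also remains open.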